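Replacing a tert-butyl with methoxy on a sulfamate carbamate

The source may report more compounds than this note shows. Statements on the series, on what has been measured and on what is new or still open speak of the compounds shown alone.

In an assay on liver for inhibition of sterol O-acyltransferase 1 (Rattus norvegicus), using microsomes (on this read-out higher numbers stand for weaker inhibition and lower numbers for stronger inhibition), compound 1 `CC(C)CN(CC(C)C)S(=O)(=O)NC(=O)Nc1c(C(C)C)cccc1C(C)C` gives 420 nM. Compound 2 `CC(C)c1cc(C(C)(C)C)cc(C(C)C)c1OC(=O)NS(=O)(=O)Oc1c(C(C)C)cccc1C(C)C` gives 8800 nM in this assay, the higher of the two numbers, and its gap to compound 1 lies beyond the scatter. Compound 3 `COc1cc(C(C)C)c(OC(=O)NS(=O)(=O)Oc2c(C(C)C)cccc2C(C)C)c(C(C)C)c1` differs from compound 2 in one place: methoxy in place of tert-butyl on an aromatic carbon. For the measured compounds named here, no measured pair shows this change, so the step is expected to be small, at most slightly toward weaker inhibition, giving a 1.4-fold higher number from compound 2 to compound 3 (0.13 log units; within the scatter). Compound 3 is therefore estimated at 12000 nM in this assay, with a range from 4000 nM to 40000 nM.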

Compound 3, half-maximal inhibitory concentration: > 25000 nM
Compound 3: no number, only a limit (the forecaster's own chance of this, stated with the estimate: 15%); at least 2.0-fold (0.31 log units) between middle value and limit.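

Swapping tert-butyl for methoxy at this position, meta to two isopropyl groups, is not a neutral change in this assay: it gives an at least 2.8-fold higher number from compound 2 to compound 3 (0.45 log units; beyond the scatter). Compound 1 and compound 2 differ in more than one place, so they could not show that this position responds to its substituent. Compound 3 has only a limit, so the step gives a minimum and not a size: the limit of > 25000 nM in this assay, at which 1 of the 3 values shown sits.

On these data alone, how far the value of compound 3 lies past that limit stays open. So does whether an amine or a longer chain at this position would bring the number back down.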